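The source may hold more compounds than are shown below. What is called first, only, known or untested is meant among the compounds shown, and "the series" means these compounds.

Measured in a functional assay on K562 cells (Homo sapiens) for antiproliferative activity, read by MTT assay, with a stated time of 72 h; a higher number here means a weaker inhibitor, a lower number a stronger inhibitor:
- compound 1 `COc1cc(C(=O)c2sc3ccccc3c2-c2ccccc2)cc(OC)c1OC`: 2100 nM
- compound 2 `COc1cc(C(=O)c2sc3ccccc3c2-c2ccc(Cl)cc2)cc(OC)c1OC`: 4200 nM
- compound 3 `COc1ccccc1-c1c(C(=O)c2cc(OC)c(OC)c(OC)c2)sc2ccccc12`: 3400 nM

Compound 3 gives 3400 nM, and it cannot be separated from the other two compounds. The data show a 1.6-fold higher number from compound 1 to compound 3 (0.21 log units; within the scatter) and a 1.2-fold lower number from compound 2 to compound 3 (0.09 log units; within the scatter).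

The next compound is compound 4 `CCOc1ccc(-c2c(C(=O)c3cc(OC)c(OC)c(OC)c3)sc3ccccc23)cc1`, which keeps the shared core and exchanges one substituted phenyl group for another: 4-ethoxyphenyl in place of 2-methoxyphenyl on an aromatic carbon. Within the data shown here, three measured steps bear on this change. The closest is a 1.2-fold lower number from compound 2 to compound 3 (0.09 log units; within the scatter), which also swaps one substituted phenyl group for another at this place. Adding a group to the plain phenyl gave a 2.0-fold higher number from compound 1 to compound 2 (0.30 log units; within the scatter) and a 1.6-fold higher number from compound 1 to compound 3 (0.21 log units; within the scatter). All three steps stay within the scatter, so no step beyond the scatter is expected in this assay. Among the measured compounds shown here, no measured compound carries a 4-ethoxyphenyl group, which leaves the estimate uncertain.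

The estimated step is a 1.1-fold lower number from compound 3 to compound 4 (0.05 log units; within the scatter). The expected value for compound 4 is 3000 nM, with an estimated range of 1200 nM to 7500 nM.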

Compound 4, half-maximal inhibitory concentration: 3100 nM
The estimate for compound 4 lay 1.0-fold (0.01 log units) below the measured number; measured number inside the range.
By their numbers in this assay, from the lowest: compounds 1, 4, 3 and 2 (each within the scatter of the next).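

In this assay, 4-ethoxyphenyl fits the pattern of the earlier groups at this place: replacing 2-methoxyphenyl gives a 1.1-fold lower number from compound 3 to compound 4 (0.04 log units; within the scatter), ethoxy in place of chloro gives a 1.4-fold lower number from compound 2 to compound 4 (0.13 log units; within the scatter), and ethoxy in place of hydrogen gives a 1.5-fold higher number from compound 1 to compound 4 (0.17 log units; within the scatter). The new result adds a two-carbon ethoxy chain to the groups tried here, and the number still does not separate from those of the plain phenyl, the 4-chlorophenyl or the 2-methoxyphenyl group. No measurement shown explains why these groups cannot be told apart.

The compounds shown leave open whether any group at this place can move the number beyond the scatter. On these data alone, what an amine, a carboxylic acid or a longer chain on this phenyl ring would do also remains unknown.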